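The source may report more compounds than this note shows. Statements on the series, on what has been measured and on what is new or still open speak of the compounds shown alone.

Of the compounds shown here, three built on one shared core have been measured in a functional assay on B16-F10 cells (Mus musculus) for antiproliferative activity, read by MTT assay, with a stated time of 48 h; a higher number here means a weaker inhibitor, a lower number a stronger inhibitor. Compound 1 `COc1ccc(-c2nn(-c3ccccc3)cc2CNc2ccc(C)cc2)cc1` gives 8380 nM. Compound 2 `Cc1ccc(NCc2cn(-c3ccccc3)nc2-c2ccc(Cl)cc2)cc1` gives 3480 nM, and compound 3 `Cc1ccc(NCc2cn(-c3ccccc3)nc2-c2ccc(Br)cc2)cc1` gives 5980 nM. Compound 2 holds the lowest of the three numbers: a 2.4-fold lower number from compound 1 to compound 2 (0.38 log units; beyond the scatter) lies beyond the scatter, while a 1.7-fold higher number from compound 2 to compound 3 (0.24 log units; within the scatter) and a 1.4-fold lower number from compound 1 to compound 3 (0.15 log units; within the scatter) stay within it. Compound 4 `Clc1ccc(-c2nn(-c3ccccc3)cc2CNc2ccc(Br)cc2)cc1` has not yet been measured; it differs from compound 2 by bromo in place of methyl on an aromatic carbon. Going by the values given here, every measured step swapped methoxy, chloro or bromo on an aromatic carbon and never touched the methyl that leaves here, so no measured step bears directly on this change. The step of a 1.0-fold higher number from compound 2 to compound 4 (0.00 log units; within the scatter) is therefore expected to stay within the scatter. Compound 4 is estimated at 3500 nM, within 1400 nM to 8500 nM.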

Compound 4, half-maximal inhibitory concentration: 3010 nM
Compound 4: the middle estimate sits 1.2-fold (0.07 log units) above what was measured; measured number inside the range.
By their numbers in this assay, from the lowest: compounds 4, 2, 3 and 1 (each within the scatter of the next, the first and the last beyond it).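

In this assay, bromo in place of methyl on the (4-methylphenyl)amino group gives a 1.2-fold lower number from compound 2 to compound 4 (0.06 log units; within the scatter), so this exchange at this position leaves the number within the scatter. Going by these compounds alone, the earlier steps all swapped methoxy, chloro or bromo elsewhere and left this methyl in place, so this is the first reading at this position. Nothing measured here offers an explanation for the result. Only methyl and bromo have been seen at this position, and a single exchange cannot show how far its insensitivity extends. As far as these compounds go, whether an amine, a carboxylic acid or a longer chain in the same place would also stay within the scatter remains open.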